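A few compounds are considered here, and "the series" means these few. Any claim that something is new, unique, unknown or untested is made for them only; others in the source may bear on it.

Compound 1 `O=C1OC(Cc2nc(-c3ccc(-c4ccccc4)cc3)no2)c2ccccc21` was examined in an ADME assay on RAW264.7 cells (Mus musculus) for cytotoxicity, read by MTT assay, with a stated time of 24 h, in the absence of a further agent; on this read-out higher numbers stand for weaker inhibition and lower numbers for stronger inhibition. Compound 1 returned only a limit, > 40000 nM. Compound 2 `CCCOc1ccc(C(O)C2OC(=O)c3c(OC)cc(OC)cc32)cc1` likewise gave only a limit, > 40000 nM. Compound 3 `COCCCOc1ccc(C(O)C2OC(=O)c3c(OC)cc(OC)cc32)cc1` also gave only a limit, > 40000 nM. Compound 3 therefore stands where every value in this set stands, at the limit of > 40000 nM in this assay, at which 3 of the 3 values shown sit. For the measured compounds named here, the single step within the set, a step that the two limits leave unreadable from compound 2 to compound 3, cannot be sized. Compound 4 `COc1cc(OC)c2c(c1)C(C(O)c1ccc(OCc3ccc(Cl)cc3)cc1)OC2=O` differs from compound 3 by 4-chlorophenyl in place of 2-methoxyethyl on a saturated chain carbon bound to an oxygen on an aromatic ring. Going by the values given here, no measured step bears on this change, and the one step available is itself unreadable, so no shift beyond the scatter can be expected. Compound 4 is expected to sit near 50000 nM, between 20000 nM and 150000 nM. This corresponds to an expected step that the limit leaves unreadable from compound 3 to compound 4.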

Compound 4, half-maximal inhibitory concentration: > 40000 nM
Compound 4: a limit, no number; the forecaster's own chance of this, stated with the estimate: 80%; the middle value is on the limit's open side.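

Compound 4 gave only a limit, and the steps to it from compound 2 and from compound 3 cannot be read. The compounds shown leave open whether any of these changes alters the read-out in this assay: the limit of > 40000 nM in this assay, at which 4 of the 4 values shown sit.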